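A Nitro Group Added to Compound 2

The source may hold more compounds than are shown below. What is called first, only, known or untested is meant among the compounds shown, and "the series" means these compounds.

- compound 1 `O=C(CCCCC1CCSS1)Nc1ccccc1Cl` gives "not active" (no number reported)
- compound 2 `O=C(CCCCC1CCSS1)Nc1cccc(C(F)(F)F)c1` gives 10.9%
- compound 3 `O=C(CCCCC1CCSS1)Nc1ccc(OC(F)(F)F)cc1` gives 8.49%

All three compounds were tested in a functional assay on KB cells (Homo sapiens) for inhibition, read by MTT assay, with a stated time of 24 h, tested at 10 ug/mL (on this read-out lower numbers stand for less inhibition of growth and higher numbers for more inhibition of growth at the one concentration tested), and differ only in the groups on the aromatic ring attached to the shared core. Only two of them have a number. Compound 2 gives 10.9% and compound 3 gives 8.49% and these two values lie within the usual scatter of each other, so they cannot be ranked. Compound 1 was reported as "not active" (no number reported) with no number.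

The next compound is compound 4 `O=C(CCCCC1CCSS1)Nc1ccc([N+](=O)[O-])c(C(F)(F)F)c1` which differs from compound 2 in one place: nitro in place of hydrogen on an aromatic carbon. A nitro takes the place of a hydrogen on an aromatic carbon, ortho to a trifluoromethyl group and para to a large group.

Among the compounds with values here, no measured pair in this small set shows what such a change does, so the expectation stays cautious. The expected step is slightly upward and stays within the scatter (a number 1.1 percentage points higher from compound 2 to compound 4 (within the scatter)) and it rests on compound 2 at 10.9% as the starting point. A result without a number, as for compound 1, also remains possible. In this assay compound 4 is estimated at 12% with an expected range from 3% to 30% at the one concentration tested.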

Compound 4, percent growth inhibition at one concentration: "not active" (no number reported)
The entry for compound 4 holds no number, so the estimate cannot be set against anything.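

In this assay, within the data shown here, compound 4 gives "not active" (no number reported) and compound 2 gives 10.9% so, with a number on only one side, no step between these two compounds can be read. On these data alone, whether adding the nitro changes growth inhibition at all, and by how much, stays open. No measurement shown here explains the result for compound 4.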